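The compounds below may be only part of what the source reports. "The series", "measured", "known", "first", "only" and "open" are said of these compounds alone.

Measured in a functional assay on CRL2813 cells (Homo sapiens) for cytotoxicity, read by sulforhodamine B assay, with a stated time of 5 days; on this read-out higher numbers stand for weaker inhibition and lower numbers for stronger inhibition:
compound 1 `O=C(Nc1ccccc1Cl)N[C@H]1CC[C@H](Oc2ccc(F)cc2)CC1` — 9100 nM
compound 2 `O=C(Nc1ccccc1I)N[C@H]1CC[C@H](Oc2ccc(F)cc2)CC1` — > 20000 nM, a limit of the assay
compound 3 `COc1ccc(NC(=O)N[C@H]2CC[C@H](Oc3ccc(F)cc3)CC2)cc1` — > 20000 nM, a limit of the assay

Compound 3 stands at the limit of the assay in this assay; no number is available for it, and the same holds for one other member of the series (the limit of > 20000 nM in this assay, at which 2 of the 3 values shown sit). Compound 4 `O=C(Nc1cccc(C(=O)O)c1)N[C@H]1CC[C@H](Oc2ccc(F)cc2)CC1` differs from compound 3 in one place: 3-carboxyphenyl in place of 4-methoxyphenyl on an amide-type nitrogen. Within the data shown here, two measured steps bear on this region of the molecule, both starting from compound 1 with its 2-chlorophenyl: an at least 2.1-fold higher number from compound 1 to compound 2 (0.34 log units; beyond the scatter) and an at least 2.1-fold higher number from compound 1 to compound 3 (0.34 log units; beyond the scatter). Each change away from compound 1 pushed the value in this assay to the limit. Among the measured compounds shown here, the step that the two limits leave unreadable from compound 2 to compound 3 gives no readable size, so the exchange of 4-methoxyphenyl for 3-carboxyphenyl has no measured precedent of its own. With compound 3 already at the limit, no improvement beyond the scatter is expected, and a further limit value is the likeliest outcome. Compound 4 is expected to give 28000 nM, within 9000 nM to 80000 nM. The expected step that the limit leaves unreadable from compound 3 to compound 4 is therefore none beyond the scatter.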

Compound 4, half-maximal inhibitory concentration: > 20000 nM
Compound 4: no number, only a limit; the forecaster's own chance of this, stated with the estimate: 70%; the middle value lies beyond the limit too.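

Working notes on the group on the amide-type nitrogen, read in this assay: a third group, 3-carboxyphenyl, now joins 2-iodophenyl and 4-methoxyphenyl at the limit, which is a limit of the assay and not a number: the limit of > 20000 nM in this assay, at which 3 of the 4 values shown sit.

Among these compounds, the only readable step for the new compound is an at least 2.1-fold higher number from compound 1 to compound 4 (0.34 log units; beyond the scatter), while the steps among the three compounds at the limit cannot be read. Compound 4 extends the earlier picture to a group that carries a hydrogen-bond donor, and this group also gives no number, so among the four groups shown only the 2-chlorophenyl of compound 1 gives one.

The compounds shown leave open whether compound 2, compound 3 and compound 4 differ at all in this assay, since none of them has a number to compare. They also leave open whether the measurable value of compound 1 depends on the chloro group, which an unsubstituted phenyl, a fluorophenyl or a bromophenyl on the same nitrogen of the shared core would test.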